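Solubility after replacing phenyl with piperidin-4-yl

The compounds below may be only part of what the source reports. "The series", "measured", "known", "first", "only" and "open" are said of these compounds alone.

Measured so far in a physicochemical assay for solubility, read by HPLC; a higher number here means a more soluble compound, a lower number a less soluble compound
- Compound 1 `Cc1cc2nn(-c3ccccc3)c(N)c2c(=O)[nH]1` gives 69 ug/mL
- Compound 2 `Nc1c2c(=O)[nH]c(-c3ccccc3)cc2nn1-c1ccccc1` gives < 1 ug/mL (a limit, not a number)

Compound 2 stands at the limit of < 1 ug/mL in this assay, at which 1 of the 2 values shown sits. Compound 3 `Nc1c2c(=O)[nH]c(C3CCNCC3)cc2nn1-c1ccccc1` carries piperidin-4-yl in place of the phenyl of compound 2, on the aromatic carbon next to the ring nitrogen: piperidin-4-yl in place of phenyl on an aromatic carbon.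

Among the compounds with values here, one measured step bears on this change, the exchange of methyl for phenyl at that carbon: an at least 69-fold lower number from compound 1 to compound 2 (1.83 log units; beyond the scatter). It is large and beyond the scatter. Because of an at least 69-fold lower number from compound 1 to compound 2 (1.83 log units; beyond the scatter) a large rise in this assay is expected once the phenyl leaves. Piperidin-4-yl is not methyl, so the size remains uncertain, and the limit on the starting compound widens the range further. The estimated step is an at least 50-fold higher number from compound 2 to compound 3 (1.69 log units; beyond the scatter). Compound 3 is expected at 50 ug/mL, with an estimated range of 8 ug/mL to 300 ug/mL.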

Compound 3, solubility: 1430 ug/mL
Estimate against measurement, compound 3: 29-fold (1.46 log units) below; the whole stated range lies below it.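

Methyl did not set the upper end at this aromatic carbon next to the ring nitrogen in this assay: piperidin-4-yl in its place gives a 21-fold higher number from compound 1 to compound 3 (1.32 log units; beyond the scatter), so a saturated ring of the same heavy-atom count as phenyl is not penalised here as phenyl is. Against phenyl, the same group gives an at least 1400-fold higher number from compound 2 to compound 3 (3.15 log units; beyond the scatter), showing that the large fall seen earlier is more than reversed at this carbon. Only a lower bound on that step is known, because compound 2 stands at a limit: the limit of < 1 ug/mL in this assay, at which 1 of the 3 values shown sits.

The compounds shown do not separate the loss of the aromatic ring from the entry of the ring nitrogen; a cyclohexyl ring at this carbon would bear on that. Going by these compounds, how an open-chain amine or a carboxylic acid would behave at this carbon also remains open.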